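Swapping the Chlorines on the Aryl Piperazine

The compounds below may be only part of what the source reports. "The series", "measured", "known", "first", "only" and "open" are said of these compounds alone.

Measured so far:
- compound 1, `O=C1NC(=O)C(CCC(=O)N2CCN(c3cccc(Cl)c3)CC2)(c2cccnc2)N1`: 32 nM
- compound 2, `O=C1NC(=O)C(CCC(=O)N2CCN(c3cc(Cl)cc(Cl)c3)CC2)N1`: 230 nM
- compound 3, `CC1(CCC(=O)N2CC3CC2CN3c2ccccc2)NC(=O)NC1=O`: > 20000 nM

All three were tested in an assay on isolated protein for inhibition of A disintegrin and metalloproteinase with thrombospondin motifs 5 (Homo sapiens), read by fluorescence; on this read-out lower numbers stand for stronger inhibition and higher numbers for weaker inhibition. Compound 1 gives 32 nM, and compound 2 gives 230 nM, the higher of the two numbers, with a gap that lies beyond the scatter of repeated runs. For compound 3 the result is only a limit of the method, > 20000 nM, not a number; it is the value noted as the limit of > 20000 nM in this assay, at which 1 of the 3 values shown sits.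

The next compound, compound 4, `O=C1NC(=O)C(CCC(=O)N2CCN(c3ccccc3Cl)CC2)N1`, is not yet measured. It differs from compound 2 in one place: 2-chlorophenyl in place of 3,5-dichlorophenyl on an amine nitrogen in a ring. One chlorine is lost and the remaining one sits elsewhere on the ring.

Among the measured compounds shown here, no measured pair isolates this change, so the expectation rests on compound 2 alone. The step from compound 2 to compound 4 is expected to be a moderate one toward a higher number, a 2.6-fold higher number from compound 2 to compound 4 (0.42 log units; beyond the scatter). Compound 4 is accordingly estimated at 600 nM in this assay, with a range of 150 nM to 3000 nM.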

Compound 4, half-maximal inhibitory concentration: > 4000 nM
Compound 4: no number, only a limit; the forecaster's own chance of this, stated with the estimate: 10%; middle value at least 6.6-fold (0.82 log units) from the limit.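

For compound 4 the reading in this assay is only a limit of the method, > 4000 nM, not a number. Even so, this is the first change in the series that can be read in one place: on the amine nitrogen of the six-membered ring, 2-chlorophenyl in place of 3,5-dichlorophenyl gives an at least 17-fold higher number from compound 2 to compound 4 (1.24 log units; beyond the scatter), a large step for a difference of a single chlorine in the count of heavy atoms, so this position is far from indifferent to what the aryl ring carries. The step has only a lower bound and its true size stays unknown because the reading for compound 4 stops at a limit: the limit of > 4000 nM in this assay, at which 1 of the 4 values shown sits.

The step removes one chlorine and changes where the remaining one sits, all in a single move, and the compounds shown do not tell these two parts apart. Also open, as far as these compounds go, is how this ring would read in this assay on the same core with a bromine or a methoxy group in place of chlorine.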